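Swapping the aniline substituent in a weakly antiproliferative series

The source may report more compounds than this note shows. Statements on the series, on what has been measured and on what is new or still open speak of the compounds shown alone.

Three compounds sharing one core were tested in a functional assay on A-431 cells (Homo sapiens) for antiproliferative activity, read by MTT assay, with a stated time of 72 h; on this read-out lower numbers stand for stronger inhibition and higher numbers for weaker inhibition. Compound 1 `COc1cc2ncnc(Nc3cccc(F)c3)c2cc1OCCCCC(=O)Nc1ccc(S(N)(=O)=O)cc1` gives 29900 nM, compound 2 `COc1cc2ncnc(Nc3ccc(F)cc3)c2cc1OCCCCC(=O)Nc1ccc(S(N)(=O)=O)cc1` gives 18600 nM, and compound 3 `COc1ccc(Nc2ncnc3cc(OC)c(OCCCCC(=O)Nc4ccc(S(N)(=O)=O)cc4)cc23)cc1OC` gives 35400 nM. Compound 3 thus shows the highest of the three numbers, though all three lie within the scatter of one another. Compound 4 `COc1cc2ncnc(Nc3ccc(OC(F)(F)F)cc3)c2cc1OCCCCC(=O)Nc1ccc(S(N)(=O)=O)cc1` differs from compound 3 only by 4-(trifluoromethoxy)phenyl in place of 3,4-dimethoxyphenyl on a nitrogen on an aromatic ring. The measured steps that bear on this change alter the same aryl group on that nitrogen: a 1.2-fold higher number from compound 1 to compound 3 (0.07 log units; within the scatter) and a 1.9-fold higher number from compound 2 to compound 3 (0.28 log units; within the scatter), neither beyond the scatter. Going by the values given here, no step toward a trifluoromethoxy group has been measured, so the expected step is a 1.2-fold lower number from compound 3 to compound 4 (0.07 log units; within the scatter), essentially nothing beyond the scatter. Compound 4 is therefore estimated at 30000 nM, with a range from 12000 nM to 75000 nM.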

Compound 4, half-maximal inhibitory concentration: 22500 nM
For compound 4 the middle estimate is 1.3-fold (0.12 log units) above the measured one, within the range that was stated.
By their numbers in this assay, from the lowest: compounds 2, 4, 1 and 3 (each within the scatter of the next).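

In this assay, placing 4-(trifluoromethoxy)phenyl on this nitrogen gives steps that all stay within the scatter (a 1.6-fold lower number from compound 3 to compound 4 (0.20 log units; within the scatter)) and (a 1.3-fold lower number from compound 1 to compound 4 (0.12 log units; within the scatter)) and (a 1.2-fold higher number from compound 2 to compound 4 (0.08 log units; within the scatter)). A group bearing three fluorine atoms therefore cannot be told apart from the fluorophenyl or 3,4-dimethoxyphenyl groups at this position, and all four compounds remain weak together. Nothing available explains this flat result. Still open, from the compounds shown here alone, is whether an amine or a carboxylic acid on this aromatic ring would produce a step beyond the scatter. Going by these compounds, a longer chain elsewhere on the shared core is equally open.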